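Longer Amine-Bearing Chain Restored on the Phenolic Oxygen

A few compounds are considered here, and "the series" means these few. Any claim that something is new, unique, unknown or untested is made for them only; others in the source may bear on it.

Compound 3 `COc1cc(/C=C/C(=O)Nc2ccccc2)ccc1O` carries a free oxygen on an aromatic ring of the shared core. Within the data shown here, in a physicochemical assay for lipophilicity, using the shake flask method, measured as octanol-water partition, at pH 7.4 (a higher number here means a more lipophilic compound, a lower number a more polar compound), compound 3 gives 1.42, the lowest of the three numbers so far, though both other compounds lie within the scatter of it: compound 1 `COc1cc(/C=C/C(=O)Nc2ccccc2)ccc1OCCCN(C)C` gives 1.55, and compound 2 `COc1cc(/C=C/C(=O)Nc2ccccc2)ccc1OCCCCN1CCCC1` gives 1.6. Compound 4 `COc1cc(/C=C/C(=O)Nc2ccccc2)ccc1OCCCCCCN(C)C` differs from compound 3 in one place: 6-(dimethylamino)hexyl in place of hydrogen on an oxygen on an aromatic ring. Among the measured compounds shown here, two measured steps bear on this change, both running the other way, from an amine-bearing chain to hydrogen: a number 0.13 log units lower from compound 1 to compound 3 (within the scatter) and a number 0.18 log units lower from compound 2 to compound 3 (within the scatter). Neither step left the scatter, so putting back a chain of the same kind would be expected to move the partition coefficient only a little. For the measured compounds named here, the chain entering compound 4 is longer than either chain whose removal was measured, and no measured pair shows what the extra length does here. The chemist therefore expects a modest rise, a number 0.48 log units higher from compound 3 to compound 4 (beyond the scatter), and estimates compound 4 at 1.9, within 1.5 to 2.4.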

Compound 4, partition coefficient: 1.69
Estimate against measurement, compound 4: 0.21 log units above, within the range that was stated.
By their numbers in this assay, from the lowest: compounds 3, 1, 2 and 4 (each within the scatter of the next).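

In this assay, 6-(dimethylamino)hexyl in place of hydrogen on the oxygen on an aromatic ring gives a number 0.27 log units higher from compound 3 to compound 4 (within the scatter) and so joins the two shorter amine-bearing chains in staying within the scatter of the free oxygen. The added chain length can also be set against those shorter chains directly, with a number 0.14 log units higher from compound 1 to compound 4 (within the scatter) and a number 0.09 log units higher from compound 2 to compound 4 (within the scatter) as the two steps, and neither can be told apart from the scatter in this assay either. Thus, across the chains shown, neither the presence of the chain on this oxygen nor its length yields a step beyond the scatter. No evidence is available to explain these results. Still open, as far as these compounds go, is whether a carboxylic acid at the chain end, or a plain alkyl chain with no amine, would give a step beyond the scatter at this oxygen. From the compounds shown here alone, a longer chain than 6-(dimethylamino)hexyl remains equally open.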